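Amino in Place of Bromo on a Shared Core

This account rests on a few compounds, and the source may have more. Where it says the series, first, only, none or still open, it means among the compounds named here.

The study takes three measured compounds that share one core and differ only in the substitution of the aromatic ring. In a physicochemical assay for lipophilicity, measured as octanol-water partition, at pH 7.4 (a lower number here means a more polar compound, a higher number a more lipophilic compound), compound 1, `CC(=O)c1cccc(NC2=NCCC3(CCCCC3)S2)c1`, gives 2.37. Compound 2, `Brc1ccc(NC2=NCCC3(CCCCC3)S2)cc1`, gives 2.53 in this assay, and compound 3, `Cc1ccc(NC2=NCCC3(CCCCC3)S2)cc1Cl`, gives 2.44. Among the measured compounds shown here, the three numbers lie within the scatter of one another, so compound 2 stands with the others rather than apart from them; the data hold no step between measured compounds.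

The compound to be measured is compound 4, `Nc1ccc(NC2=NCCC3(CCCCC3)S2)cc1`. It differs from compound 2 in one place: amino in place of bromo on an aromatic carbon. The group that leaves brings no hydrogen-bond donor or acceptor, the group that enters brings one of each.

For the measured compounds named here, no measured pair shows this change, so the expectation rests on compound 2 at 2.53 and the change alone. The step from compound 2 to compound 4 in this assay is expected to be a number 1.63 log units lower from compound 2 to compound 4 (beyond the scatter), a move beyond the scatter toward a lower number. Compound 4 is therefore estimated at 0.9, between 0.3 and 1.5.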

Compound 4, distribution coefficient: 1.88
Estimate against measurement, compound 4: 0.98 log units below; measured number above the stated range.
By their numbers in this assay, from the lowest: compound 4; then compounds 1, 3 and 2 (each within the scatter of the next).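

In this assay, among the compounds shown here, amino in place of bromo, on an aromatic carbon para to a large group, gives a number 0.65 log units lower from compound 2 to compound 4 (beyond the scatter) and so provides the first measured step on the shared core. The earlier compounds shown here, whose numbers all lay within the scatter of one another, showed no such separation; this pair shows that a change at this one place can carry the number beyond the scatter. The data offer no measurement that accounts for the size of the step.

The compounds shown leave open whether a hydroxyl or a carboxylic acid at the same place would give a step of similar size. They also leave open whether amino would give the same step on another aromatic carbon or on a core with a different substituent.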